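This account rests on a few compounds, and the source may have more. Where it says the series, first, only, none or still open, it means among the compounds named here.

Compound 1 `COc1cc(/C=C/C(=O)/C=C/c2ccccc2)ccc1OCc1cn(CCCCOc2cc(=O)oc3ccccc23)nn1` and compound 2 `COc1cc(/C=C/C(=O)/C=C/c2cc(OC)c(OC)c(OC)c2)ccc1OCc1cn(CCCCOc2cc(=O)oc3ccccc23)nn1` share one core; compound 2 differs by 3,4,5-trimethoxyphenyl in place of phenyl on a double-bonded chain carbon bound to a double-bonded chain carbon. In a functional assay on HCT-116 cells (Homo sapiens) for inhibition, read by sulforhodamine B assay, with a stated time of 48 h, tested at 50 uM (a higher number here means more inhibition of growth at the concentration tested, a lower number less inhibition of growth), compound 1 gives 34%, and compound 2 gives 63%, a step of a number 29 percentage points higher from compound 1 to compound 2 (beyond the scatter). Compound 3 `COc1cc(/C=C/C(=O)/C=C/c2ccccc2)ccc1OCc1cn(CCCCCOc2cc(=O)oc3ccccc23)nn1` has a core whose difference from the core of compound 1 is not broken down here; in this assay compound 3 gives 24%, which lies within the scatter of compound 1 and well below compound 2. Compound 4 `COc1cc(/C=C/C(=O)/C=C/c2cc(OC)c(OC)c(OC)c2)ccc1OCc1cn(CCCCCOc2cc(=O)oc3ccccc23)nn1` is compound 3 with 3,4,5-trimethoxyphenyl in place of phenyl on a double-bonded chain carbon bound to a double-bonded chain carbon, the same change at the same place. Because the earlier step was a number 29 percentage points higher from compound 1 to compound 2 (beyond the scatter), a step of similar size is expected here, a number 28 percentage points higher from compound 3 to compound 4 (beyond the scatter). Compound 4 is therefore estimated at 52% in this assay, expected to fall between 36% and 68%.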

Compound 4, percent growth inhibition at one concentration: 53%
The estimate for compound 4 lay 1 percentage points below the measured number, and the stated range covers the measured number.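

In this assay, 3,4,5-trimethoxyphenyl in place of phenyl gives a number 29 percentage points higher from compound 3 to compound 4 (beyond the scatter). The change carried from one core to the other with its size intact: the same change on two cores in this assay, a number 29 percentage points higher (beyond the scatter) from compound 1 to compound 2 and a number 29 percentage points higher (beyond the scatter) from compound 3 to compound 4, 0 percentage points apart, within the scatter of two such steps. This shows that the step held on these two cores in this one assay at a single concentration, but it does not show why the step occurs or whether it would hold on a more different core.

The compounds shown leave open whether a phenyl carrying one methoxy group, or an aminophenyl, in the same place would give all, part or none of this step. They also leave open whether the step would survive on a core with a longer chain.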